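The source may hold more compounds than are shown below. What is called first, only, known or untested is meant among the compounds shown, and "the series" means these compounds.

Compound 1 `O=C(N/N=C/c1ccncc1)c1cc2cc(Br)ccc2oc1=O` and compound 2 `CCOc1ccc2nc(Cl)c(/C=N/NC(=O)c3cc4cc(Br)ccc4oc3=O)cc2c1` share the same core. Going by the values given here, in a functional assay on PANC-1 cells (Homo sapiens) for antiproliferative activity, read by fluorescence and resazurin assay, with a stated time of 48 h (a higher number here means a weaker inhibitor, a lower number a stronger inhibitor), compound 1 gives 25700 nM, the highest of the two numbers so far; compound 2 gives 17000 nM, and the gap to compound 1 lies within the scatter, so nothing can be read from it. Compound 3 `O=C(N/N=C/c1ccncc1)c1cc2ccccc2oc1=O` is not yet measured; it differs from compound 1 in one place: hydrogen in place of bromo on an aromatic carbon. Among the compounds with values here, no step between measured compounds covers this change, so only a small move is expected, toward a weaker inhibitor if any. The estimate for compound 3 in this assay is 32000 nM, with a range of 13000 nM to 80000 nM. The step this estimate implies, a 1.2-fold higher number from compound 1 to compound 3 (0.10 log units; within the scatter), is expected to be near the scatter.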

Compound 3, half-maximal inhibitory concentration: 9750 nM
Beside the measured number, compound 3's estimate is 3.3-fold (0.52 log units) above it, and the stated range ends above it.
By their numbers in this assay, from the lowest: compounds 3, 2 and 1 (each within the scatter of the next, the first and the last beyond it).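

Replacing bromo with hydrogen on this aromatic carbon, meta to a fused ring and para to a fused ring, gives a 2.6-fold lower number from compound 1 to compound 3 (0.42 log units; beyond the scatter) in this assay. Going by these compounds alone, this is the first step that isolates this position, and with the rest of compound 1 unchanged, bromo is not needed for the antiproliferative activity seen here. Nothing available explains the shift.

From the compounds shown here alone, whether the same change holds with the substituents of compound 2 remains open. So does how a chloro, methoxy or amino group would compare with hydrogen and bromo at this carbon.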